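From hydroxy to methylsulfanyl: what to expect for compound 4

A few compounds are considered here, and "the series" means these few. Any claim that something is new, unique, unknown or untested is made for them only; others in the source may bear on it.

In an ADME assay on MT4 cells (Homo sapiens) for cytotoxicity, read by MTT assay, with a stated time of 4 days (a higher number here means that more compound is tolerated, a lower number that less compound is tolerated), compound 1 `O=C(COc1cccc2ccccc12)N/N=C/c1ccc(O)cc1` gives 26.5 ug/mL and sits in the middle of the three measured numbers. Compound 2 `C/C(=N\NC(=O)COc1cccc2ccccc12)c1ccc(O)cc1O` stands higher at 59.9 ug/mL and compound 3 `C/C(=N\NC(=O)COc1cccc2ccccc12)c1ccccc1O` lower at 11.3 ug/mL on the same scale. Compound 4 `CSc1ccc(/C=N/NC(=O)COc2cccc3ccccc23)cc1` has not been measured yet. It carries methylsulfanyl in place of hydroxy on an aromatic carbon and differs from compound 1 nowhere else. Within the data shown here, only one measured step also removes a hydroxy. Hydrogen in place of hydroxy gave a 5.3-fold lower number from compound 2 to compound 3 (0.72 log units; beyond the scatter) in that case, and although that is a different replacement, a modest fall is expected here. The estimated step is a 1.9-fold lower number from compound 1 to compound 4 (0.28 log units; within the scatter) in this assay and remains a loose guide. For compound 4 the expected value is 14 ug/mL with 5 ug/mL to 40 ug/mL as its estimated range.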

Compound 4, half-maximal cytotoxic concentration: 68.3 ug/mL
Estimate against measurement, compound 4: 4.9-fold (0.69 log units) below; measured number outside the range, above it.
By their numbers in this assay, from the lowest: compound 3; then compound 1; then compounds 2 and 4 (each within the scatter of the next).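

Methylsulfanyl in place of hydroxy at this position gives a 2.6-fold higher number from compound 1 to compound 4 (0.41 log units; beyond the scatter) in this assay, so the hydroxy and its hydrogen-bond donor are not needed here for more compound to be tolerated. The one earlier step that removed a hydroxy went the other way, so losing a hydroxy does not lower the number in every compound shown. No measured evidence explains this rise.

On these data alone, whether the rise follows the loss of hydroxy or the arrival of methylsulfanyl stays open. Methoxy at this place on compound 1 would help to separate the two.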